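The source may hold more compounds than are shown below. What is called first, only, known or untested is meant among the compounds shown, and "the series" means these compounds.

Measured compounds:
compound 1, `O=Cc1cccc(OCc2cn(Cc3ccccc3)nn2)c1` — > 50000 nM
compound 2, `COc1cc(Cn2cc(COc3cccc(/C=C4\C(=O)Nc5ccccc54)c3)nn2)cc(OC)c1` — 33800 nM

In a functional assay on HeLa cells (Homo sapiens) for inhibition, read by MTT assay, with a stated time of 48 h (on this read-out lower numbers stand for stronger inhibition and higher numbers for weaker inhibition), compound 1 gives only a limit, > 50000 nM, and no number. Among the compounds with values here, compound 2 is therefore the only compound with a number in this assay, and it gives 33800 nM. Within the data shown here, the one point of comparison is the limit of > 50000 nM in this assay, at which 1 of the 2 values shown sits, so compound 2 stands as the single quantified entry, with compound 1 sitting at the limit and not placeable against it.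

Compound 3, `COc1cc(Cn2cc(COc3cccc(/C=C4/C(=O)Nc5ccccc54)c3)nn2)cc(OC)c1`, is to be measured in this assay. It differs from compound 2 in one respect: the two compounds have the same atoms and bonds and differ only in configuration as drawn: 1 of 1 stereo elements differ; a double bond is drawn Z in compound 2 and E in compound 3. Among the measured compounds shown here, no step between two measured compounds of this set concerns such a change, so no measured reference exists for it. Given that, the expected step is small, with no clear direction and likely inside the usual scatter of repeated measurements, with a real chance that only a limit is returned.

Compound 3 is expected to give about 40000 nM in this assay, within 12000 nM to 130000 nM. The expected step of a 1.2-fold higher number from compound 2 to compound 3 (0.07 log units; within the scatter) is estimated to lie near the scatter of this assay.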

Compound 3, half-maximal inhibitory concentration: 22000 nM
For compound 3 the middle estimate is 1.8-fold (0.26 log units) above the measured one; the measured number falls inside the stated range.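

The series now holds its first readable step in this assay: a 1.5-fold lower number from compound 2 to compound 3 (0.19 log units; within the scatter). This step lies within the scatter, so at this double bond the Z and E forms as drawn cannot be told apart on this read-out, and the pair gives no ground for preferring either configuration. The reading concerns configuration alone, with no other structural change mixed into it: the fact that compounds 2 and 3 differ only in the configuration as drawn.

Compound 1 remains a limit, > 50000 nM, and not a number, so steps involving it cannot be read. Open, on these data alone, is whether an amine or a carboxylic acid in place of the methoxy groups would move the number beyond the scatter, and whether the Z and E forms would still read alike on a core carrying such a group.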